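The source may hold more compounds than are shown below. What is called first, only, known or untested is meant among the compounds shown, and "the series" means these compounds.

Of the compounds shown here, three sharing one core have been measured in an ADME assay on cells for inhibition of cytochrome P450 11B1, mitochondrial (Homo sapiens), read by HPLC, with a stated time of 60 min; a higher number here means a weaker inhibitor, a lower number a stronger inhibitor. Compound 1 `CCc1ncncc1-c1nc2cc(F)c(F)cc2n1C1CC1` gives 3330 nM. Compound 2 `CC(C)c1ncncc1-c1nc2cc(F)c(F)cc2n1C1CC1` gives 1910 nM. Compound 3 `N#Cc1ncncc1-c1nc2cc(F)c(F)cc2n1C1CC1` gives 4990 nM. Among these, compound 3 has the highest number: the gap a 1.5-fold higher number from compound 1 to compound 3 (0.18 log units; within the scatter) is within the scatter, while the gap a 2.6-fold higher number from compound 2 to compound 3 (0.42 log units; beyond the scatter) is beyond it, so compound 3 is a modestly weaker inhibitor than compound 2 only.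

Compound 4 `CNc1ncncc1-c1nc2cc(F)c(F)cc2n1C1CC1` differs from compound 3 in one place: methylamino in place of cyano on an aromatic carbon. Going by the values given here, no measured step concerns a methylamino group, so none bears directly on this change. Among the compounds with values here, the steps that touch the cyano group, a 1.5-fold higher number from compound 1 to compound 3 (0.18 log units; within the scatter) and a 2.6-fold higher number from compound 2 to compound 3 (0.42 log units; beyond the scatter), show that swapping this group for an alkyl group moved the number only slightly or modestly, and no step is large.

Compound 4 is therefore expected to land near compound 3, with the step of a 1.4-fold lower number from compound 3 to compound 4 (0.15 log units; within the scatter) a guess of direction only. The estimate for compound 4 in this assay is 3500 nM, within a range from 1200 nM to 10000 nM.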

Compound 4, half-maximal inhibitory concentration: 390 nM
Compound 4: middle estimate off by 9.0-fold (0.95 log units), on the high side, and the stated range ends above it.
By their numbers in this assay, from the lowest: compound 4; then compounds 2, 1 and 3 (each within the scatter of the next, the first and the last beyond it).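

In this assay, going by these compounds alone, this position proves far more sensitive than the earlier compounds showed: methylamino in place of cyano gives a 13-fold lower number from compound 3 to compound 4 (1.11 log units; beyond the scatter), the first large step. The change also separates methylamino from both alkyl groups, with a 4.9-fold lower number from compound 2 to compound 4 (0.69 log units; beyond the scatter) and an 8.5-fold lower number from compound 1 to compound 4 (0.93 log units; beyond the scatter), so compound 4 is the strongest inhibitor of the four. Methylamino brings one hydrogen-bond donor where cyano had none, but no measurement here links that difference, or any other feature of the group, to the lower number.

The compounds shown leave open whether the lower number needs the hydrogen on that nitrogen, which a dimethylamino group would test, or the methyl, which a plain amino group would test. They also leave open how a longer chain on the nitrogen, such as ethylamino, would read.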